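Sulfonyl pyrazole in place of free pyrazole on the amide

A few compounds are considered here, and "the series" means these few. Any claim that something is new, unique, unknown or untested is made for them only; others in the source may bear on it.

Compound 1 `CNC(=O)N1CCCc2ccc(NC(=O)c3ccc(-c4cc[nH]n4)cc3)cc21` stands at the higher of the two numbers in hand: in a functional assay on MV4-11 cells (Homo sapiens) for antiproliferative activity, with a stated time of 6 days, tested at 6.25 uM (on this read-out lower numbers stand for a weaker effect and higher numbers for a stronger effect at the one concentration tested), compound 1 gives 99.1%. Compound 2 `CNC(=O)N1CCCc2ccc(NC(=O)c3cccc(-c4cc[nH]n4)c3)cc21` lies within the scatter of that figure, as in this assay compound 2 gives 89.7%. Compound 3 `CNC(=O)N1CCCc2ccc(NC(=O)c3ccc(-c4cnn(S(C)(=O)=O)c4)cc3)cc21` differs from compound 1 by 1-(methylsulfonyl)-1H-pyrazol-4-yl in place of 1H-pyrazol-3-yl on an aromatic carbon. Among the compounds with values here, no measured pair covers this change, so its size is open. A modest fall, possibly beyond the scatter, is expected, a number 19.1 percentage points lower from compound 1 to compound 3 (beyond the scatter). Compound 3 is estimated at 80%, with a range from 45% to 99%.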

Compound 3, a percentage reported as inhibition, at one concentration (the size of the read-out at that concentration, not a potency): 40.2%
Compound 3: middle estimate off by 39.8 percentage points, on the high side, and the stated range ends above it.
By their numbers in this assay, from the lowest: compound 3; then compounds 2 and 1 (each within the scatter of the next).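

In this assay, the place para to a large group proves sensitive to what it carries: the step is a number 58.9 percentage points lower from compound 1 to compound 3 (beyond the scatter) for 1-(methylsulfonyl)-1H-pyrazol-4-yl in place of 1H-pyrazol-3-yl. This single swap removes the hydrogen-bond donor, adds the methylsulfonyl group and moves the ring attachment, so the step cannot assign the fall to any one of these. Nothing in hand explains the fall. Open, as far as these compounds go, is whether the methylsulfonyl group or the attachment carries the loss. A plain 1H-pyrazol-4-yl or 1-methyl-1H-pyrazol-4-yl group here would separate the two.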